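From difluoromethoxy to piperidin-1-yl, with only limits so far

The source may report more compounds than this note shows. Statements on the series, on what has been measured and on what is new or still open speak of the compounds shown alone.

Measured in an ADME assay on Huh7.5.1 cells (Homo sapiens) for cytotoxicity, read by WST assay, with a stated time of 48 h; on this read-out lower numbers stand for higher toxicity in this test and higher numbers for lower toxicity in this test (all three are limits):
Compound 1 `Cc1c(-c2ccc(Cc3ccc(C(C)(C)C)cc3)cc2)[nH]c2cccc(F)c2c1=O` gives > 5000 nM as a limit
Compound 2 `Cc1c(-c2ccc(Cc3ccc(C(C)(O)C(F)(F)F)cc3)cc2)[nH]c2cccc(F)c2c1=O` gives > 2500 nM as a limit
Compound 3 `Cc1c(-c2ccc(Cc3ccc(OC(F)F)cc3)cc2)[nH]c2cccc(F)c2c1=O` gives > 5000 nM as a limit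

None of these readings is an exact number. Compound 3 has > 5000 nM in this assay and that is a limit. Compound 4 `Cc1c(-c2ccc(Cc3ccc(N4CCCCC4)cc3)cc2)[nH]c2cccc(F)c2c1=O` differs from compound 3 by piperidin-1-yl in place of difluoromethoxy on an aromatic carbon and is otherwise the same. The closest guides are swaps of groups on an aromatic carbon, a step that the two limits leave unreadable from compound 1 to compound 3 and a step that the two limits leave unreadable from compound 2 to compound 3 and neither has a size to carry over. The expected change is therefore a number no higher from compound 3 to compound 4 (the limit leaves the size open) and no step beyond the scatter is expected. For compound 4 the estimate is 5000 nM with an expected range from 2000 nM to 12000 nM and the reading may again be only a limit.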

Compound 4, half-maximal cytotoxic concentration: > 10000 nM
Compound 4: a limit, no number; the forecaster's own chance of this, stated with the estimate: 75%; at least 2.0-fold (0.30 log units) between middle value and limit.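

Going by these compounds alone, compound 1, compound 2, compound 3 and compound 4 all give only limits in this assay, so no step between them can be read. The compounds shown leave open whether swapping these groups changes toxicity at all.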